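Antiproliferative Read-outs for Three Analogues and a Fourth

The compounds below may be only part of what the source reports. "The series", "measured", "known", "first", "only" and "open" are said of these compounds alone.

The measured compounds are:
compound 1, `CCc1ccc2nc(C(=O)Nc3c(F)cc(-c4cccc(F)c4)cc3F)c(C)c(O)c2c1`, 31.2%;
compound 2, `Cc1c(C(=O)Nc2c(F)cc(-c3cccc(F)c3)cc2F)nc2ccc(OC(F)(F)F)cc2c1O`, 26.4%;
compound 3, `CCc1ccc2nc(C(=O)Nc3c(F)cc(-c4cccc(F)c4)cc3F)c(C)c(C(=O)O)c2c1`, 15.2%.

All three were tested in a functional assay on Hep 3B2 cells (Homo sapiens) for antiproliferative activity, read by MTT assay, with a stated time of 24 h, tested at 3.7 ug/mL; a lower number here means a weaker effect, a higher number a stronger effect of the compound at the concentration tested. Compound 3 stands lowest of the three numbers in this assay; the nearest is compound 2, which lies higher by a margin beyond the scatter, and the furthest is compound 1, higher still. The step of a number 16 percentage points lower from compound 1 to compound 3 (beyond the scatter) shows the loss that accompanies carboxy in place of hydroxy on an aromatic carbon.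

Compound 4, `Cc1c(C(=O)Nc2c(F)cc(-c3cccc(F)c3)cc2F)nc2ccc(C(F)(F)F)cc2c1C(=O)O`, has not yet been measured. It differs from compound 3 by trifluoromethyl in place of ethyl on an aromatic carbon, on an aromatic carbon of a six-membered aromatic ring of carbon only, part of a fused or bridged system of two rings. Within the data shown here, no measured step carries exactly this change. The closest is a number 4.8 percentage points lower from compound 1 to compound 2 (within the scatter), where trifluoromethoxy replaced ethyl on an aromatic carbon and the number stayed within the scatter. On that basis compound 4 is expected to show a number 2.2 percentage points lower from compound 3 to compound 4 (within the scatter), no step beyond the scatter. The estimate for compound 4 in this assay is 13%, with a range from 3% to 25%.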

Compound 4, a percentage reported as inhibition, at one concentration (the size of the read-out at that concentration, not a potency): 21.3%
Compound 4: middle estimate off by 8.3 percentage points, on the low side; measured number inside the range.
By their numbers in this assay, from the lowest: compounds 3, 4, 2 and 1 (each within the scatter of the next, the first and the last beyond it).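

In this assay the exchange of ethyl for trifluoromethyl on this aromatic carbon comes to a number 6.1 percentage points higher from compound 3 to compound 4 (within the scatter) and so adds a second replacement of ethyl here that stays within the scatter. The earlier replacement, trifluoromethoxy for ethyl, was read with hydroxy on the core, whereas this one is read with carboxy, so a fluorine-bearing group in place of ethyl on this carbon has now been seen with both. Nothing available explains this result or connects it to any property of the groups.

From the compounds shown here alone, how an amine, a nitrile or a longer alkyl chain would read on this carbon remains open. So does whether carboxy in place of hydroxy brings the same loss with trifluoromethyl on the core as it did with ethyl.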